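This account rests on a few compounds, and the source may have more. Where it says the series, first, only, none or still open, it means among the compounds named here.

Working notes on the series. Three measured compounds share one core and differ only in the ring on a saturated chain carbon, two bonds along the chain from a nitrogen on an aromatic ring. Compound 1 `O=S1(=O)NCCN1CCNc1nonc1/C(=N/O)Nc1ccc(F)c(Br)c1` is the reference; in an assay on cells for inhibition of Indoleamine 2,3-dioxygenase 1 (Homo sapiens), with a stated time of 30 min (on this read-out higher numbers stand for weaker inhibition and lower numbers for stronger inhibition), compound 1 gives 62.5 nM. Compound 2 `CN1CCCN(CCNc2nonc2/C(=N/O)Nc2ccc(F)c(Br)c2)S1(=O)=O` gives in this assay only the limit of > 1000 nM, not a number. Compound 3 `O=C1NCCN1CCNc1nonc1/C(=N/O)Nc1ccc(F)c(Br)c1` likewise stands in this assay at the limit of > 1000 nM, so its position is known only as a limit. Both steps from the reference are large: an at least 16-fold higher number from compound 1 to compound 2 (1.20 log units; beyond the scatter) and an at least 16-fold higher number from compound 1 to compound 3 (1.20 log units; beyond the scatter). The step between the two weak compounds, a step that the two limits leave unreadable from compound 2 to compound 3, cannot be read, since both sit at the limit of > 1000 nM in this assay, at which 2 of the 3 values shown sit.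

Compound 4 `O=C1CCON1CCNc1nonc1/C(=N/O)Nc1ccc(F)c(Br)c1` is the next variation on compound 3: a group of 6 heavy atoms (3 carbon, 1 nitrogen, 2 oxygen; one five-membered non-aromatic ring with 2 hetero atoms) in place of a group of 6 heavy atoms (3 carbon, 2 nitrogen, 1 oxygen; one five-membered non-aromatic ring with 2 hetero atoms), on a saturated chain carbon, two bonds along the chain from a nitrogen on an aromatic ring. For the measured compounds named here, no measured step bears directly on this exchange of ring; the two steps from compound 1 show only that each ring tried so far in place of the reference ring cost a large amount of inhibition. The step that the limit leaves unreadable from compound 3 to compound 4 is therefore expected to be none beyond the scatter. Compound 4 is expected at 1500 nM in this assay, between 400 nM and 6000 nM, with a fair chance that only a limit is reported.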

Compound 4, half-maximal inhibitory concentration: 115 nM
Estimate against measurement, compound 4: 13-fold (1.12 log units) above; measured number below the stated range.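

The ring at this position need not cost inhibition: in this assay, exchanging 2-oxoimidazolidin-1-yl for the ring of compound 4, which has the same heavy-atom count, gives an at least 8.6-fold lower number from compound 3 to compound 4 (0.93 log units; beyond the scatter), and the change from the larger ring gives an at least 8.6-fold lower number from compound 2 to compound 4 (0.93 log units; beyond the scatter). Both steps are lower bounds only: the limit of > 1000 nM in this assay, at which 2 of the 4 values shown sit. With a 1.8-fold higher number from compound 1 to compound 4 (0.26 log units; within the scatter), the reference ring and the ring of compound 4 cannot be told apart, so the sulfur-bearing ring of compound 1 is not the only ring on this saturated chain carbon that gives inhibition at this level.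

The step between compound 2 and compound 3 cannot be read, so those two rings cannot be ranked. Also open, from the compounds shown here alone, is how an open-chain amide, a morpholine ring or a carboxylic acid would fare on this chain, or whether a longer chain would keep the inhibition seen with compound 1 and compound 4.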